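Removing the glucose unit from a dihydroxyphenyl diol glycoside

The source may report more compounds than this note shows. Statements on the series, on what has been measured and on what is new or still open speak of the compounds shown alone.

Compound 1 `Oc1ccc(CC[C@@H](O)C[C@H](O)CCc2ccc(O)c(O)c2)cc1O` and compound 2 `OC[C@H]1O[C@@H](O[C@H](CCc2ccc(O)c(O)c2)C[C@H](O)CCc2ccc(O)c(O)c2)[C@H](O)[C@@H](O)[C@@H]1O` share a core and differ only in that compound 1 has hydrogen in place of 3,4,5-trihydroxy-6-(hydroxymethyl)oxan-2-yl on an oxygen on a saturated carbon. For the measured compounds named here, in a functional assay on HSC-2 cells (Homo sapiens) for cytotoxicity, read by MTT assay (a higher number here means a weaker inhibitor, a lower number a stronger inhibitor), compound 1 gives 54 ug/mL, while compound 2 gives 92 ug/mL; the step of a 1.7-fold lower number from compound 2 to compound 1 (0.23 log units; within the scatter) is the single direct comparison of this change available so far. Compound 3 `OC[C@H]1O[C@@H](O[C@H](CCc2ccc(O)cc2)C[C@H](O)CCc2ccc(O)cc2)[C@H](O)[C@@H](O)[C@@H]1O` carries the same sugar on a different core, and the difference between the two cores is not broken down here. In this assay compound 3 gives 157 ug/mL, which is the highest of the three numbers and stands near the value of compound 2.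

Compound 4 `Oc1ccc(CC[C@@H](O)C[C@H](O)CCc2ccc(O)cc2)cc1` has not been measured. Going by the values given here, it differs from compound 3 by hydrogen in place of 3,4,5-trihydroxy-6-(hydroxymethyl)oxan-2-yl on an oxygen on a saturated carbon, and this is the same change as the one from compound 2 to compound 1, at the same place on the chain. Among the compounds with values here, with only one precedent, the expectation for compound 4 rests entirely on that pair. The step of a 1.7-fold lower number from compound 3 to compound 4 (0.22 log units; within the scatter) is expected to be small because the earlier step of a 1.7-fold lower number from compound 2 to compound 1 (0.23 log units; within the scatter) was itself small. On the second core the sugar is therefore expected to matter about as little as on the first. Compound 4 is expected to give 95 ug/mL in this assay, with a plausible range from 50 ug/mL to 180 ug/mL.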

Compound 4, half-maximal inhibitory concentration: 231 ug/mL
The estimate for compound 4 lay 2.4-fold (0.39 log units) below the measured number, outside the stated range (above it).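

In this assay, putting hydrogen in place of 3,4,5-trihydroxy-6-(hydroxymethyl)oxan-2-yl on an oxygen on a saturated carbon gives a 1.5-fold higher number from compound 3 to compound 4 (0.17 log units; within the scatter), so on this second core, as on the first, the exchange leaves the number within the scatter. For the compounds shown here, although the two steps are printed with opposite signs, they cannot be told apart, and the series gives no sign that the outcome of this exchange depends on the core: the same change on two cores in this assay, a 1.7-fold lower number (0.23 log units; within the scatter) from compound 2 to compound 1 and a 1.5-fold higher number (0.17 log units; within the scatter) from compound 3 to compound 4, 2.5-fold (0.40 log units) apart, within the scatter of two such steps This does not show that the sugar has no effect on any core, nor does it fix a direction or a size for the step, since the comparison rests on only two pairs, compound 2 with compound 1 and compound 3 with compound 4, and steps this small could hide a modest difference between the cores.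

The compounds shown leave open whether any group on that oxygen can move the number beyond the scatter, for instance a methyl ether, an acetyl ester or a chain ending in a carboxylic acid. They also leave open what an amine would do in place of that oxygen, and whether the same sugar on the other hydroxyl of the chain would behave as it does here.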